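Taking one fluoro group off compound 3

This account rests on a few compounds, and the source may have more. Where it says the series, first, only, none or still open, it means among the compounds named here.

Values in a functional assay on PC-3 cells (Homo sapiens) for cytotoxicity, read by MTT assay, with a stated time of 72 h; a lower number here means a stronger inhibitor, a higher number a weaker inhibitor:
- compound 1 `CNC(=O)c1cc(Oc2ccc(NC(=O)c3cc(-c4ccc(Br)cc4)ncn3)cc2)ccn1`: > 100000 nM, a limit of the assay
- compound 2 `CCc1ccc(-c2cc(C(=O)Nc3ccc(Oc4ccnc(C(=O)NC)c4)cc3)ncn2)cc1`: 29300 nM
- compound 3 `CNC(=O)c1cc(Oc2ccc(NC(=O)c3cc(-c4ccc(F)cc4)ncn3)cc2F)ccn1`: > 100000 nM, a limit of the assay

Compound 3 gives > 100000 nM, which is a limit and not a number. Compound 4 `CNC(=O)c1cc(Oc2ccc(NC(=O)c3cc(-c4ccc(F)cc4)ncn3)cc2)ccn1` differs from compound 3 in one place: hydrogen in place of fluoro on an aromatic carbon. In words, this is hydrogen in place of fluoro on an aromatic carbon, ortho to a (2-(methylcarbamoyl)pyridin-4-yl)oxy group.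

Going by the values given here, no measured pair tests this change directly. Among the compounds with values here, the only measured step concerns a different place, with ethyl in place of bromo on an aromatic carbon: an at least 3.4-fold lower number from compound 1 to compound 2 (0.53 log units; beyond the scatter). It shows that a single change can yield a measurable number in this small set. Compound 4, however, has fluoro where compound 2 has ethyl, so it lacks the group that accompanied that step. The remaining guide is the limit of > 100000 nM in this assay, at which 2 of the 3 values shown sit. A small move toward a lower number is therefore the most that is expected in this assay, and compound 4 may well stay at the limit.

The expected change is an at least 1.4-fold lower number from compound 3 to compound 4 (0.15 log units; that floor lies within the scatter).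

For compound 4, the estimated value is 70000 nM, with an expected range from 25000 nM to 100000 nM.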

Compound 4, half-maximal inhibitory concentration: > 100000 nM
Compound 4: a limit, no number; the forecaster's own chance of this, stated with the estimate: 60%; middle value at least 1.4-fold (0.15 log units) away from the limit.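

In this assay, taking off the fluoro group ortho to a (2-(methylcarbamoyl)pyridin-4-yl)oxy group leaves compound 4 at a limit of the assay, not at a number. The steps from compound 3 and from compound 1 to compound 4 join two limits and cannot be read, so neither the fluoro group on this ring nor the swap of bromo for fluoro on the other ring shows a measurable effect. The comparison that can be read is fluoro in place of ethyl, an at least 3.4-fold higher number from compound 2 to compound 4 (0.53 log units; beyond the scatter), which gives the ethyl group of compound 2 a second step from the limit and leaves compound 2 as the only compound here with a number: the limit of > 100000 nM in this assay, at which 3 of the 4 values shown sit.

Still open, on these data alone, is whether the fluoro group ortho to a (2-(methylcarbamoyl)pyridin-4-yl)oxy group has any effect in a compound that gives a number, such as one carrying the ethyl group of compound 2. Also open, as far as these compounds go, is whether the lower number belongs to ethyl alone, or whether a longer chain such as propyl, or a methoxy group, in its place would lower the number further.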